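Benzanilide cytotoxicity notes: from compound 1 toward compound 3

The compounds below may be only part of what the source reports. "The series", "measured", "known", "first", "only" and "open" are said of these compounds alone.

Measured in an ADME assay on HEK293 cells (Homo sapiens) for cytotoxicity, read by reporter gene assay and resazurin assay, with a stated time of 48 h; on this read-out lower numbers stand for higher toxicity in this test and higher numbers for lower toxicity in this test:
- compound 1 `COc1ccc(Br)cc1C(=O)Nc1ccc(Sc2nc3ccccc3s2)cc1`: > 100000 nM, a limit of this assay rather than a number
- compound 2 `O=C(Nc1cccc(Cl)c1)c1cccc(Br)c1`: 51000 nM

Compound 1 stands at the limit of this assay, so only a range is known for it: it sits at the limit of > 100000 nM in this assay, at which 1 of the 2 values shown sits, and its true value is not resolved. For the measured compounds named here, compound 2, which shares the amide but carries a different pair of rings, gives 51000 nM in this assay; no step between compound 1 and compound 2 is computed, and the two values show only that compound 2 returns a number while compound 1 does not.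

Compound 3 `O=C(Nc1ccc(Sc2nc3ccccc3s2)cc1)c1cc(Br)cc(Br)c1` keeps the core of compound 1 and differs in one place: 3,5-dibromophenyl in place of 5-bromo-2-methoxyphenyl on a carbonyl carbon.

Going by the values given here, no measured step anchors this change. Given that compound 1 rests at a limit, the step from compound 1 to compound 3 is expected to be none beyond the scatter, as a number no higher from compound 1 to compound 3 (the limit leaves the size open), with a fair chance that this assay again reports only a limit. Compound 3 is therefore estimated at 100000 nM, within a range of 40000 nM to 250000 nM.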

Compound 3, half-maximal cytotoxic concentration: > 100000 nM
Compound 3 was reported as a limit; the forecaster's own chance of this, stated with the estimate: 60%; the middle value lies on the limit itself.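

Compound 1 and compound 3 both rest at a limit in this assay, so no step can be read for 3,5-dibromophenyl in place of 5-bromo-2-methoxyphenyl: the limit of > 100000 nM in this assay, at which 2 of the 3 values shown sit. The compounds shown leave open where the true values of compound 1 and compound 3 lie, and whether this change on the carbonyl carbon shifts the read-out at all.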